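This account rests on a few compounds, and the source may have more. Where it says the series, first, only, none or still open, it means among the compounds named here.

Measured compounds in a toxicity assay on HepG2 2.2.15 cells (Homo sapiens) for cytotoxicity, read by CellTiter-Glo; on this read-out lower numbers stand for higher toxicity in this test and higher numbers for lower toxicity in this test:

Compound 1 `O=C1CC(Oc2ncc(F)cn2)CN1c1cnn2c1CN(C(=O)Nc1cc(F)c(F)c(F)c1)C(C1CC1)C2`: 96200 nM
Compound 2 `C[C@H]1Cn2ncc(N3CC(c4ccccc4)CC3=O)c2CN1S(=O)(=O)Nc1cc(F)c(F)c(F)c1`: reported only as the limit > 2000 nM
Compound 3 `C[C@H]1Cn2ncc(N3CC(c4ccccc4)CC3=O)c2CN1C(=O)NCc1cc(F)c(F)c(F)c1`: reported only as the limit > 2000 nM

Compound 1 is the only one of the three for which this assay returns an actual number, 96200 nM. For compound 2 the result is a limit of the assay, > 2000 nM, not a measured value. For compound 3 likewise only a limit is known, > 2000 nM. Going by the values given here, two of the three results therefore sit at that limit (the limit of > 2000 nM in this assay, at which 2 of the 3 values shown sit), and compounds 2 and 3 differ from compound 1 in several places at once, so no single step between measured compounds can be read from these three.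

Compound 4 `O=C1CC(Oc2ncccn2)CN1c1cnn2c1CN(C(=O)Nc1cc(F)c(F)c(F)c1)C(C1CC1)C2` has not yet been tested in this assay. It differs from compound 1 in one place only: hydrogen in place of fluoro on an aromatic carbon. Loss of a single fluorine with nothing but a hydrogen in its place is a small change, and no measured pair here shows what such a change does to this read-out. The expectation is therefore a step from compound 1 to compound 4 no larger than the usual scatter, in no particular direction, a 1.0-fold lower number from compound 1 to compound 4 (0.00 log units; within the scatter). Compound 4 is thus estimated at 96000 nM, within a range from 40000 nM to 200000 nM.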

Compound 4, half-maximal cytotoxic concentration: > 200000 nM
Compound 4: only a limit was reported; the forecaster's own chance of this, stated with the estimate: 30%; at least 2.0-fold (0.31 log units) between middle value and limit.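

In this assay, going by these compounds alone, replacing the fluoro of the 5-fluoropyrimidin-2-yl group with hydrogen, which leaves pyrimidin-2-yl, gives an at least 2.0-fold higher number from compound 1 to compound 4 (0.31 log units; beyond the scatter), the first change in a single place that can be read in this set. The result for compound 4 is a limit of the assay, not a number: the limit of > 200000 nM in this assay, at which 1 of the 4 values shown sits. On this read-out a higher number stands for lower toxicity in the test, so this one fluorine, on an aromatic carbon para to a large group, makes a difference beyond the usual scatter, although nothing here tells why.

On these data alone, it remains open how another group at this same carbon, such as chloro, methyl or an amine, would compare with fluoro and hydrogen. Within the data shown here, it also remains open whether the same exchange of fluoro for hydrogen would move the number in the same direction on a different core, as the single pair here speaks only for the core of compound 1.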